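Swapping a Urea for a Chlorinated Amide

The source may report more compounds than this note shows. Statements on the series, on what has been measured and on what is new or still open speak of the compounds shown alone.

Compound 1 `COC(=O)c1ccc2c(ccn2-c2cccc(NC(=O)c3cccc(C(F)(F)F)c3)c2)n1` — in a functional assay on A375P cells (Homo sapiens) for cytotoxicity, read by MTT assay (a lower number here means a stronger inhibitor, a higher number a weaker inhibitor), compound 1 reaches only the limit of > 10000 nM.
Compound 2 `COC(=O)c1ccc2c(ccn2-c2cccc(NC(=O)Nc3cccc(C(F)(F)F)c3)c2)n1` — in this assay compound 2 likewise sits at the limit of > 10000 nM.

Compound 1 carries an amide and compound 2 the matching urea. The step between them, a step that the two limits leave unreadable from compound 1 to compound 2, cannot be read as a number because of the limit of > 10000 nM in this assay, at which 2 of the 2 values shown sit. Compound 3 `COC(=O)c1ccc2c(ccn2-c2cccc(NC(=O)c3ccc(Cl)c(C(F)(F)F)c3)c2)n1` differs from compound 2 by 4-chloro-3-(trifluoromethyl)phenyl in place of (3-(trifluoromethyl)phenyl)amino on a carbonyl carbon. Going by the values given here, the only measured step touching this position is the unreadable one, so it gives no size and no direction, and nothing is known about the added chlorine. With both measured neighbours sitting at the limit, compound 3 is expected to stay there as well, an expected step that the limit leaves unreadable from compound 2 to compound 3. Compound 3 is therefore estimated at 20000 nM, somewhere between 6000 nM and 60000 nM, and most likely reported again only as a limit.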

Compound 3, half-maximal inhibitory concentration: > 10000 nM
Compound 3: no number, only a limit; the forecaster's own chance of this, stated with the estimate: 80%; the middle value is on the limit's open side.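

Compound 3 yields no readable step against compound 1 or compound 2, because each of the three values is a limit and not a number: the limit of > 10000 nM in this assay, at which 3 of the 3 values shown sit.

The compounds shown leave open whether the urea in place of the amide, or the added chloro, changes activity at all in this assay.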